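Para-Trifluoromethyl Analogue Expected to Remain Without Cytotoxicity

The compounds below may be only part of what the source reports. "The series", "measured", "known", "first", "only" and "open" are said of these compounds alone.

Compound 3 (`Cc1ccc(C(=O)NN=C2CC(c3ccccc3)NC(c3ccccc3)C2)cc1`) is the starting point of this step. In a toxicity assay on BJ cells (Homo sapiens) for cytotoxicity, read by MTT assay, with a stated time of 24 h (on this read-out lower numbers stand for stronger inhibition and higher numbers for weaker inhibition), compound 3 gives > 400000 nM, which is a limit of the assay and not a number. Compound 1 (`O=C(NN=C1CC(c2ccccc2)NC(c2ccccc2)C1)c1ccc(F)cc1`) gives > 400000 nM in this assay, again a limit. Compound 2 (`COc1ccc(C(=O)NN=C2CC(c3ccccc3)NC(c3ccccc3)C2)cc1`) gives > 400000 nM, also a limit. The three substituents on the benzamide ring thus share one outcome, (the limit of > 400000 nM in this assay, at which 3 of the 3 values shown sit). The steps among them, a step that the two limits leave unreadable from compound 1 to compound 2, a step that the two limits leave unreadable from compound 1 to compound 3 and a step that the two limits leave unreadable from compound 2 to compound 3, therefore carry no readable size, and compound 3 cannot be ranked against compound 1 or compound 2.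

Compound 4 (`O=C(NN=C1CC(c2ccccc2)NC(c2ccccc2)C1)c1ccc(C(F)(F)F)cc1`) differs from compound 3 only by trifluoromethyl in place of methyl on an aromatic carbon. Within the data shown here, none of the measured steps tells how this change would move this assay, so no step beyond the scatter can be expected in either direction, and the outcome is most likely another limit. Compound 4 is therefore estimated at 500000 nM, with a range from 150000 nM to 2000000 nM. The step this implies, a step that the limit leaves unreadable from compound 3 to compound 4, is expected to be unreadable, like those already seen.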

Compound 4, half-maximal inhibitory concentration: > 400000 nM
Compound 4 gave a limit, no number; the forecaster's own chance of this, stated with the estimate: 85%; the middle value does not contradict the limit.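

Among these compounds, compound 4 ends at a limit and not a number, as do compound 1, compound 2 and compound 3, so no step from compound 4 to any of them can be read in this assay: the limit of > 400000 nM in this assay, at which 4 of the 4 values shown sit. On these data alone, the order of these four compounds in this assay remains open.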